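A few compounds are considered here, and "the series" means these few. Any claim that something is new, unique, unknown or untested is made for them only; others in the source may bear on it.

Two compounds of a shared core carry measurements here. Compound 1 `Nc1nc(N)c2c(Cl)c(NCc3cccc(Br)c3)ccc2n1` gives 7.59 nM in an assay for inhibition of Dihydrofolate reductase (Rattus norvegicus); on this read-out higher numbers stand for weaker inhibition and lower numbers for stronger inhibition. Compound 2 `Nc1nc(N)c2c(Cl)c(Br)ccc2n1` gives 100 nM in this assay, the higher of the two numbers and thus the weaker inhibitor, separated from compound 1 by a gap that lies beyond the scatter. Compound 3 `Nc1nc(N)c2c(Cl)cccc2n1` has not yet been measured in this assay. It differs from compound 2 in one place: hydrogen in place of bromo on an aromatic carbon. For the measured compounds named here, no measured pair follows this same change, so the size of the step can only be guessed. Removing a single heavy atom from a compound that already stands at the weak end of the series is expected to cost some potency, yet not a large amount; the step of a 2.5-fold higher number from compound 2 to compound 3 (0.40 log units; beyond the scatter) is therefore estimated to run toward higher numbers by a modest margin. Compound 3 is accordingly expected to come out at about 250 nM, within a range from 80 nM to 800 nM.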

Compound 3, half-maximal inhibitory concentration: 562 nM
The estimate for compound 3 lay 2.2-fold (0.35 log units) below the measured number; the range from low to high includes it.
By their numbers in this assay, from the lowest: compound 1; then compound 2; then compound 3.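

In this assay, for the compounds shown here, hydrogen in place of bromo on this aromatic carbon gives a 5.6-fold higher number from compound 2 to compound 3 (0.75 log units; beyond the scatter), the first direct reading of what this position contributes. Even a single heavy atom here, ortho to a chloro group, therefore makes a difference that stands clear of the scatter, on a compound that already lay at the weak end of the series. Nothing at hand explains why the loss of bromo counts for this much.

The compounds shown leave open whether a smaller or different group on this carbon, such as fluoro, methyl, methoxy or a plain amine, would stand closer to compound 2 or to compound 3. They also leave open how the same change would read with the chloro group replaced by hydrogen.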